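A few compounds are considered here, and "the series" means these few. Any claim that something is new, unique, unknown or untested is made for them only; others in the source may bear on it.

Measured so far:
- compound 1 `Nc1nc(-c2ccc(Cl)cc2)c(CC(=O)O)s1` — in an in vitro functional assay on HEK285-7 cells for antagonist activity at prostaglandin D2 receptor 2 (Homo sapiens), read by BRET and beta-arrestin recruitment (on this read-out lower numbers stand for stronger inhibition and higher numbers for weaker inhibition), compound 1 gives > 100000 nM
- compound 2 `O=C(O)Cc1sc(C(c2ccc(F)cc2)c2ccc(F)cc2)nc1-c1ccnc(F)c1` — in this assay compound 2 gives 4.7 nM

The result for compound 1 is not a number but a limit of the assay, namely (the limit of > 100000 nM in this assay, at which 1 of the 2 values shown sits). Among the compounds with values here, compound 2 therefore stands alone: its value is the only real number among the two results, and there is no second measured number to set it against, so no step between measured compounds is available here.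

The next compound, compound 3 `O=C(O)Cc1sc(C(c2ccc(F)cc2)c2ccc(F)cc2)nc1-c1cccc(F)c1`, keeps everything in compound 2 except one ring: 3-fluorophenyl in place of 2-fluoropyridin-4-yl on an aromatic carbon. Within the data shown here, because no measured pair differs in just one place, the size of such a swap cannot be read off from the data, and the expectation rests on the change itself. The exchange of one six-membered aromatic ring for another of the same size is expected to move the read-out little, likely no further than the usual scatter of repeated measurements, in either direction.

Compound 3 is thus estimated at 6 nM in this assay, with a plausible range from 1.5 nM to 25 nM, which means an expected step of a 1.3-fold higher number from compound 2 to compound 3 (0.11 log units; within the scatter).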

Compound 3, half-maximal inhibitory concentration: 18 nM
For compound 3 the middle estimate is 3.0-fold (0.48 log units) below the measured one, and the stated range covers the measured number.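

Within the data shown here, this is the first step that can be read, and it shows that the ring on this aromatic carbon, next to the ring nitrogen, is not freely interchangeable: 3-fluorophenyl in place of 2-fluoropyridin-4-yl gives a 3.8-fold higher number from compound 2 to compound 3 (0.58 log units; beyond the scatter) even though the new ring is also six-membered and aromatic and has the same number of heavy atoms. The change costs some inhibition without removing it, since in this assay compound 3 still gives 18 nM, so a ring of carbon only, with no hydrogen-bond acceptor, is still accepted at this position. Nothing available here measures a property of either ring or otherwise bears on why the number rises.

This single pair cannot show whether the difference belongs to the ring nitrogen alone or would hold with other groups on the ring. A plain phenyl ring, or a chlorine, methoxy or nitrile group in place of the fluorine, would show how much the fluorine contributes on each ring and how far this position tolerates change.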